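Notes on the amide substituent of the shared core

The compounds below may be only part of what the source reports. "The series", "measured", "known", "first", "only" and "open" are said of these compounds alone.

Compound 1 `CCNC(=O)C1=CC(C)(C)Oc2ccc([N+](=O)[O-])cc21` stands lowest of the three numbers in a functional assay (muscle tissue) with Rattus norvegicus as the target (a higher number here means that more compound is needed for the effect, a lower number that less compound is needed), where compound 1 gives 4.57 nM. Compound 2 `CCCCNC(=O)C1=CC(C)(C)Oc2ccc([N+](=O)[O-])cc21` gives 21.9 nM and compound 3 `CC1(C)C=C(C(=O)NC2CC2)c2cc([N+](=O)[O-])ccc2O1` gives 32.4 nM. The unmeasured compound 4 `CC1(C)C=C(C(=O)NCCO)c2cc([N+](=O)[O-])ccc2O1` differs from compound 1 by hydroxy in place of hydrogen on a saturated chain carbon, two bonds along the chain from an amide-type nitrogen. Within the data shown here, the one measured step at this place, a 4.8-fold higher number from compound 1 to compound 2 (0.68 log units; beyond the scatter), raised the number; the other change on the amide-type nitrogen, a 7.1-fold higher number from compound 1 to compound 3 (0.85 log units; beyond the scatter), did likewise. Among the measured compounds shown here, no measured step introduces a hydroxy, so the expectation rests on these two modest rises alone. A modest rise beyond the scatter is therefore expected, a 2.6-fold higher number from compound 1 to compound 4 (0.42 log units; beyond the scatter). Compound 4 is estimated at 12 nM, with a range from 3.5 nM to 40 nM.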

Compound 4, half-maximal effective concentration: 182 nM
The estimate for compound 4 lay 15-fold (1.18 log units) below the measured number; the measured number lies above the stated range.
By their numbers in this assay, from the lowest: compound 1; then compounds 2 and 3 (each within the scatter of the next); then compound 4.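

Hydroxy on the saturated chain carbon, two bonds along the chain from the amide-type nitrogen, gives the largest step seen at this position in this assay (a 40-fold higher number from compound 1 to compound 4 (1.60 log units; beyond the scatter)), whereas the earlier changes were only modest, and the same place carrying ethyl stays lower (an 8.3-fold higher number from compound 2 to compound 4 (0.92 log units; beyond the scatter)). The 2-hydroxyethyl group also stands above cyclopropyl on the amide-type nitrogen (a 5.6-fold higher number from compound 3 to compound 4 (0.75 log units; beyond the scatter)), which leaves compound 4 highest of the four. Nothing available explains this rise.

From the compounds shown here alone, whether the rise belongs to hydroxy itself or would also follow a methoxy or an amine at this place stays open. So does the effect of a longer chain carrying the hydroxy.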